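The source may report more compounds than this note shows. Statements on the series, on what has been measured and on what is new or still open speak of the compounds shown alone.

Within an assay for inhibition of Polyunsaturated fatty acid 5-lipoxygenase (Homo sapiens), read by HPLC, with stated times of 15 min and 10 min (a higher number here means a weaker inhibitor, a lower number a stronger inhibitor), compound 1 `CC(C)C(C#Cc1cccc(C(=O)NCc2ccccc2C(F)(F)F)c1)N(O)C(N)=O` gives 500 nM, the lowest of the two numbers in hand; compound 2 `COc1ccc(CNC(=O)c2cccc(C#CC(C)N(O)C(N)=O)c2)c(C(F)(F)F)c1`, which in this assay gives 1700 nM, sits beyond the scatter of it. Compound 3 `CCCC(C#Cc1cccc(C(=O)NCc2ccccc2C(F)(F)F)c1)N(O)C(N)=O` carries the change (propyl in place of isopropyl on a saturated chain carbon bound to an amide-type nitrogen and a triple-bonded carbon). For the measured compounds named here, no measured pair shows this exchange, so its effect is not known from the series. The expected step from compound 1 to compound 3 in this assay is a 1.2-fold higher number from compound 1 to compound 3 (0.08 log units; within the scatter), no more than the usual scatter in either direction. Compound 3 is thus estimated to give 600 nM, within a range of 250 nM to 1500 nM.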

Compound 3, half-maximal inhibitory concentration: 300 nM
Compound 3: the middle estimate sits 2.0-fold (0.30 log units) above what was measured; low and high end bracket the measured number.
By their numbers in this assay, from the lowest: compounds 3 and 1 (each within the scatter of the next); then compound 2.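

In this assay, moving from the branched isopropyl to the unbranched propyl on a saturated chain carbon bound to an amide-type nitrogen and a triple-bonded carbon gives a 1.7-fold lower number from compound 1 to compound 3 (0.22 log units; within the scatter), so this exchange leaves the number unresolved from the scatter. At this position, the branch is therefore shown to be dispensable for holding the number in this range. No evidence in hand bears on this result. Open, on these data alone, is whether a longer chain such as butyl, a cyclopropyl ring or an amine at this carbon would keep the number in this range.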